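Working notes: from compound 2 to compound 4

The source may hold more compounds than are shown below. What is called first, only, known or untested is meant among the compounds shown, and "the series" means these compounds.

compound 1 `COc1ncc(-c2ccc3ncc(NCc4ccc(C(F)(F)F)cc4)c(OC)c3c2)cc1NS(=O)(=O)c1ccc(F)cc1F` (3220 nM)
compound 2 `CCNc1cnc2ccc(-c3cnc(OC)c(NS(=O)(=O)c4ccc(F)cc4F)c3)cc2c1OC` (1850 nM)
compound 3 `COc1ncc(-c2ccc3ncc(NCC4CCN(C(C)=O)CC4)c(OC)c3c2)cc1NS(=O)(=O)c1ccc(F)cc1F` (1930 nM)

All three values come from a functional assay on HCT-116 cells (Homo sapiens) for antiproliferative activity, read by sulforhodamine B assay, with a stated time of 72 h; on this read-out higher numbers stand for weaker inhibition and lower numbers for stronger inhibition. On these numbers compound 2 cannot be separated from the other two compounds, as a 1.7-fold lower number from compound 1 to compound 2 (0.24 log units; within the scatter) and a 1.0-fold higher number from compound 2 to compound 3 (0.02 log units; within the scatter) show.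

The next compound is compound 4 `COc1ncc(-c2ccc3ncc(NCC4CCN(S(C)(=O)=O)CC4)c(OC)c3c2)cc1NS(=O)(=O)c1ccc(F)cc1F`, which carries 1-(methylsulfonyl)piperidin-4-yl in place of methyl on a saturated chain carbon bound to a nitrogen on an aromatic ring.

Going by the values given here, the closest precedent is compound 3, with 1-acetylpiperidin-4-yl at the same place, and its step is the small one already given. The step of a 1.7-fold lower number from compound 1 to compound 3 (0.22 log units; within the scatter) also bears on the change, since it is made at this same place. Across the three measured compounds, no step at this place leaves the scatter, and none of them goes against that pattern. Among the compounds with values here, no measured compound holds the methylsulfonyl group, so this reading rests on compound 3 as the nearest match.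

No step beyond the scatter is expected in this assay, and no direction can be argued. The expected step is a 1.1-fold higher number from compound 2 to compound 4 (0.03 log units; within the scatter) as an estimate. For compound 4 the estimated value is 2000 nM, with an expected range from 1000 nM to 4000 nM.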

Compound 4, half-maximal inhibitory concentration: 1360 nM
The estimate for compound 4 lay 1.5-fold (0.17 log units) above the measured number; the range from low to high includes it.
By their numbers in this assay, from the lowest: compounds 4, 2, 3 and 1 (each within the scatter of the next, the first and the last beyond it).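

In this assay, going by these compounds alone, the change from 4-(trifluoromethyl)phenyl to 1-(methylsulfonyl)piperidin-4-yl gives the first step at this place that leaves the scatter, with a 2.4-fold lower number from compound 1 to compound 4 (0.37 log units; beyond the scatter) as a modest difference. The other two new steps stay within the scatter, with a 1.4-fold lower number from compound 2 to compound 4 (0.13 log units; within the scatter) for the change from methyl and a 1.4-fold lower number from compound 3 to compound 4 (0.15 log units; within the scatter) for methylsulfonyl in place of acetyl on an amine nitrogen in a ring, so compound 4 cannot be separated from compound 2 or compound 3. Nothing available gives a reason for any of these steps.

The compounds shown leave open how a piperidin-4-yl with a free ring amine, or with a carboxylic acid or a longer alkylsulfonyl chain on the ring nitrogen, would read at this place. They also leave open whether the separation from compound 1 belongs to the methylsulfonyl group itself, since the steps to compound 2 and compound 3 from compound 1 stay within the scatter while that to compound 4 only just leaves it.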